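The source may hold more compounds than are shown below. What is called first, only, known or untested is meant among the compounds shown, and "the series" means these compounds.

Compound 1 `CC1=C(/C=C/C(=O)/C=C/c2ccccc2F)C(C)(C)CCC1O`: 10400 nM
Compound 2 `CC1=C(/C=C/C(=O)/C=C/c2cc(C(F)(F)F)ccc2F)C(C)(C)CCC1O`: 3600 nM
Compound 3 `CC1=C(/C=C/C(=O)/C=C/c2c(F)cccc2C(F)(F)F)C(C)(C)CCC1O`: 8800 nM

In a functional assay on PC-3 cells (Homo sapiens) for cytotoxicity, read by MTT assay, with a stated time of 72 h (a lower number here means a stronger inhibitor, a higher number a weaker inhibitor), compound 1 gives the highest number of the three measured compounds. The step of a 2.9-fold lower number from compound 1 to compound 2 (0.46 log units; beyond the scatter) came with trifluoromethyl in place of hydrogen on an aromatic carbon, while the step of a 1.2-fold lower number from compound 1 to compound 3 (0.07 log units; within the scatter) came with the same kind of change at another aromatic carbon. Compound 4 `COc1cccc(/C=C/C(=O)/C=C/C2=C(C)C(O)CCC2(C)C)c1` differs from compound 1 by 3-methoxyphenyl in place of 2-fluorophenyl on a double-bonded chain carbon bound to a double-bonded chain carbon. For the measured compounds named here, neither measured step removes the fluorine or brings in methoxy, so no step tests this change directly, and the two steps from compound 1 together span a small range. The expected step is therefore a 1.2-fold lower number from compound 1 to compound 4 (0.06 log units; within the scatter), not clearly beyond the scatter in either direction. Compound 4 is estimated at 9000 nM, within 3000 nM to 27000 nM.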

Compound 4, half-maximal inhibitory concentration: 6500 nM
Estimate against measurement, compound 4: 1.4-fold (0.14 log units) above; measured number inside the range.
By their numbers in this assay, from the lowest: compounds 2, 4, 3 and 1 (each within the scatter of the next, the first and the last beyond it).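

In this assay, for the compounds shown here, the earlier steps kept the fluorine and added trifluoromethyl, whereas this one replaces the whole 2-fluorophenyl group with 3-methoxyphenyl, giving a 1.6-fold lower number from compound 1 to compound 4 (0.20 log units; within the scatter). So at this place on the chain, a ring without fluorine and with one hydrogen-bond acceptor keeps the number within the usual scatter of compound 1. No measurement here explains this result.

Going by these compounds alone, the single swap cannot separate the loss of fluorine from the arrival of methoxy. From the compounds shown here alone, how a plain phenyl ring, or a ring bearing an amine or a carboxylic acid, would behave here remains open.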